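Aryl variation on the aromatic nitrogen: outlook for compound 4

A few compounds are considered here, and "the series" means these few. Any claim that something is new, unique, unknown or untested is made for them only; others in the source may bear on it.

Compound 1 `N#CC1=C(N)Oc2c(N)cc3nc4ccccc4nc3c2C12C(=O)N(Cc1cnnn1-c1ccccc1Br)c1ccccc12`: in a functional assay on HepG2 cells (Homo sapiens) for antiproliferative activity, read by MTT assay, with a stated time of 48 h (on this read-out lower numbers stand for stronger inhibition and higher numbers for weaker inhibition), compound 1 gives 38000 nM.
Compound 2 `COc1ccccc1-n1nncc1CN1C(=O)C2(C(C#N)=C(N)Oc3c(N)cc4nc5ccccc5nc4c32)c2ccccc21`: compound 2 gives only the assay limit > 50000 nM.
Compound 3 `CCOc1ccc(-n2nncc2CN2C(=O)C3(C(C#N)=C(N)Oc4c(N)cc5nc6ccccc6nc5c43)c3ccccc32)cc1`: compound 3 gives only the assay limit > 50000 nM.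

Compound 3 stands at a limit rather than at a number, and it is not alone there: the limit of > 50000 nM in this assay, at which 2 of the 3 values shown sit. Its only readable connection to a numbered compound is an at least 1.3-fold higher number from compound 1 to compound 3 (0.11 log units; that floor lies within the scatter); the pair of limits gives a step that the two limits leave unreadable from compound 2 to compound 3.

Compound 4 `COc1ccc(OC)c(-n2nncc2CN2C(=O)C3(C(C#N)=C(N)Oc4c(N)cc5nc6ccccc6nc5c43)c3ccccc32)c1` differs from compound 3 in one place: 2,5-dimethoxyphenyl in place of 4-ethoxyphenyl on an aromatic nitrogen.

Among the compounds with values here, two measured steps bear on this change. The move to compound 3 gave an at least 1.3-fold higher number from compound 1 to compound 3 (0.11 log units; that floor lies within the scatter), and the exchange of one alkoxyphenyl for another gave a step that the two limits leave unreadable from compound 2 to compound 3. Compound 2, which carries 2-methoxyphenyl on the aromatic nitrogen, also sits at the limit. Within the data shown here, no step among the three shows a readable gain on this side of the scaffold.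

Compound 4 is therefore expected to stay at the limit, with a step that the limit leaves unreadable from compound 3 to compound 4 expected to be no step beyond the scatter. The estimate for compound 4 is 65000 nM, with the expected range from 25000 nM to 150000 nM.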

Compound 4, half-maximal inhibitory concentration: 45100 nM
Compound 4: middle estimate off by 1.4-fold (0.16 log units), on the high side, and the stated range covers the measured number.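

In this assay, an alkoxyphenyl group on the aromatic nitrogen now gives a readable number, so the limits of compound 2 and compound 3 do not hold for every such group. The exchange of 2-bromophenyl for 2,5-dimethoxyphenyl gives a 1.2-fold higher number from compound 1 to compound 4 (0.07 log units; within the scatter), so the two aryl groups are not separated on this read-out. Going by these compounds, the other two steps, an at least 1.1-fold lower number from compound 3 to compound 4 (0.04 log units; that floor lies within the scatter) and an at least 1.1-fold lower number from compound 2 to compound 4 (0.04 log units; that floor lies within the scatter), have floors that show no gain beyond the scatter, and their true sizes stay unknown.

On these data alone, the true positions of compound 2 and compound 3 stay open, as each is a limit and not a number: the limit of > 50000 nM in this assay, at which 2 of the 4 values shown sit. Also open, as far as these compounds go, is whether an amine or a carboxylic acid on the aryl ring, or a longer chain in place of the alkoxy groups, would move the read-out beyond the scatter.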